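The compounds below may be only part of what the source reports. "The series", "measured", "known", "first", "only" and "open" are said of these compounds alone.

Measured compounds:
Compound 1 `N#Cc1cccc(-c2ccc(CN(CCN3CCCC3)C(=O)Nc3cc(Cl)cc(Cl)c3)cc2)c1`: > 3000 nM
Compound 2 `N#Cc1cccc(-c2ccc(CN(CCN3CCCC3)C(=O)Nc3ccc(F)c(C(F)(F)F)c3)cc2)c1`: > 3000 nM
Compound 3 `N#Cc1cccc(-c2ccc(CN(CC(=O)Nc3cc(Cl)cc(Cl)c3)C(=O)CN3CCCC3)cc2)c1`: > 3000 nM

Among the compounds with values here, in a functional assay for antagonist activity at melanin-concentrating hormone receptor 2 (Homo sapiens) (on this read-out lower numbers stand for stronger inhibition and higher numbers for weaker inhibition), every value so far is a limit of the assay and not a number (the limit of > 3000 nM in this assay, at which 3 of the 3 values shown sit). Compound 3 therefore stands only at that limit, with nothing to set it apart from the other two. Within the data shown here, the one step between measured compounds, a step that the two limits leave unreadable from compound 1 to compound 2, is unreadable for the same reason.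

Compound 4 `N#Cc1cccc(-c2ccc(CN(CC(=O)Nc3cc(Cl)cc(Cl)c3)C(=O)CN3CC[C@H](O)C3)cc2)c1` differs from compound 3 by hydroxy in place of hydrogen on a saturated ring carbon. Among the measured compounds shown here, no measured step touches this change, so no direction can be read for it. Given that compound 3 sits at the limit, compound 4 is expected to sit there too, with the step that the limit leaves unreadable from compound 3 to compound 4 unreadable in this assay. The estimate for compound 4 is 6000 nM, range 2000 nM to 20000 nM.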

Compound 4, inhibition constant: > 3000 nM
Compound 4: a limit, no number; the forecaster's own chance of this, stated with the estimate: 80%; the middle value lies beyond the limit too.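

In this assay, no step can be read between compound 3 and compound 4, because both values are limits and not numbers: the limit of > 3000 nM in this assay, at which 4 of the 4 values shown sit.

The compounds shown leave open which structural change, if any, would give a readable number in this assay.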